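A few compounds are considered here, and "the series" means these few. Any claim that something is new, unique, unknown or untested is made for them only; others in the source may bear on it.

Measured compounds in an ADME assay on KB cells (Homo sapiens) for cytotoxicity; on this read-out lower numbers stand for an effect already at smaller amounts and higher numbers for an effect only at larger amounts of compound:
compound 1, `CCOc1c(OC)c(OC)cc2c1C(=O)[C@]1(OC)C=C[C@H]2N(C(=O)OCC(C)C)N1C(=O)OCC(C)C`, > 300 ug/mL
compound 2, `CCOC(=O)N1[C@@H]2C=C[C@@](OC)(C(=O)c3c2cc(OC)c(OC)c3OCc2ccccc2F)N1C(=O)OCC`, 99.7 ug/mL
compound 3, `COC(=O)N1[C@@H]2C=C[C@@](OC)(C(=O)c3c2cc(OC)c(OC)c3OCc2ccccc2F)N1C(=O)OC`, 137 ug/mL

Compound 1 gives no number in this assay, only the limit > 300 ug/mL; where it truly stands above that limit is open. Going by the values given here, compound 2 gives 99.7 ug/mL and compound 3 gives 137 ug/mL; the two values lie within the usual scatter of each other, and no single-point step connects either of them to compound 1, since both differ from it in more than one place. Among the compounds with values here, the only evidence on this series is therefore (the limit of > 300 ug/mL in this assay, at which 1 of the 3 values shown sits), and it sets no slope at all.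

The compound not yet measured is compound 4, `COc1cc2c(c(O)c1OC)C(=O)[C@]1(OC)C=C[C@H]2N(C(=O)OCC(C)C)N1C(=O)OCC(C)C`. It differs from compound 1 in one place: hydrogen in place of ethyl on an oxygen on an aromatic ring. Nothing in the data shown lets a direction be read for this change, so the step from compound 1 to compound 4 in this assay is expected to stay within the scatter, with a slightly greater chance of a reported number than of another limit. Compound 4 is expected at 250 ug/mL, between 100 ug/mL and 600 ug/mL, which means an expected step of an at least 1.2-fold lower number from compound 1 to compound 4 (0.07 log units; that floor lies within the scatter).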

Compound 4, concentration for half-maximal effect: > 300 ug/mL
Compound 4: no number, only a limit; the forecaster's own chance of this, stated with the estimate: 45%; middle value at least 1.2-fold (0.07 log units) from the limit.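

Compound 4 stays at a limit in this assay and reads > 300 ug/mL just as compound 1 does, so no step can be read between compound 1 and compound 4. Still open is where the two compounds truly stand, and so whether ethoxy to hydroxy changes this read-out at all, with the only evidence being: the limit of > 300 ug/mL in this assay, at which 2 of the 4 values shown sit.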